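This account rests on a few compounds, and the source may have more. Where it says the series, first, only, none or still open, it means among the compounds named here.

In an ADME assay on Vero cells (Chlorocebus sabaeus) for cytotoxicity, read by MTT assay (a higher number here means a weaker inhibitor, a lower number a stronger inhibitor), compound 1 (`CN(Cc1ccc(F)cc1)c1cc(C(=O)Nc2ccccc2)ncn1`) gives 297000 nM and compound 2 (`CN(Cc1ccc(Cl)cc1)c1cc(C(=O)Nc2ccccc2)ncn1`) gives 207000 nM, so compound 2 stands within the scatter of compound 1. Compound 3 (`CN(Cc1ccc(C(F)(F)F)cc1)c1cc(C(=O)Nc2ccccc2)ncn1`) carries trifluoromethyl in place of chloro on an aromatic carbon. Among the compounds with values here, the only measured step that bears on this change is chloro in place of fluoro on an aromatic carbon, a 1.4-fold lower number from compound 1 to compound 2 (0.16 log units; within the scatter), and it stays within the scatter. No step beyond the scatter is therefore expected in this assay. The estimated step is a 1.1-fold lower number from compound 2 to compound 3 (0.04 log units; within the scatter). For compound 3 the expected value is 190000 nM, with an estimated range of 85000 nM to 400000 nM.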

Compound 3, half-maximal inhibitory concentration: 258000 nM
Beside the measured number, compound 3's estimate is 1.4-fold (0.13 log units) below it, and the stated range covers the measured number.
By their numbers in this assay, from the lowest: compounds 2, 3 and 1 (each within the scatter of the next).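

In this assay the position on an aromatic carbon para to a large group now holds trifluoromethyl, with 4 heavy atoms, in place of chloro, with 1 heavy atom, and the change gives a 1.2-fold higher number from compound 2 to compound 3 (0.10 log units; within the scatter), while the change from fluoro gives a 1.2-fold lower number from compound 1 to compound 3 (0.06 log units; within the scatter). Among fluoro, chloro and trifluoromethyl at this position, no step lies beyond the scatter. No measurement at hand explains this result. As far as these compounds go, whether an amine, a carboxylic acid or a longer chain at this position would give a step beyond the scatter remains open.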